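Hydrogen for fluoro on the sulfamoyl anilide: cytotoxicity

A few compounds are considered here, and "the series" means these few. Any claim that something is new, unique, unknown or untested is made for them only; others in the source may bear on it.

Within the data shown here, compound 1 `CC(C)n1ncc2c(C(=O)Nc3ccc(F)c(S(N)(=O)=O)c3)cc(-c3cccs3)nc21` carries the only number in an ADME assay on LLC-MK2 cells (Macaca mulatta) for cytotoxicity, read by spectrophotometry and crystal violet staining, with a stated time of 4 days (a lower number here means that less compound is tolerated, a higher number that more compound is tolerated), at 50000 nM. Compound 2 `CC(C)n1ccc2c(C(=O)Nc3ccc(F)cc3)cc(-c3cccs3)nc21` gives in this assay only a limit, > 200000 nM. Compound 3 `CC(C)n1ncc2c(C(=O)Nc3ccc(F)cc3)cc(-c3ccsc3)nc21` likewise gives only a limit in this assay, > 200000 nM. Among the measured compounds shown here, two of the three values thus sit at the limit of > 200000 nM in this assay, at which 2 of the 3 values shown sit, so no step between measured compounds can be read, and the difference between compound 1 and the two limits is all that the set shows. Compound 4 `CC(C)n1ncc2c(C(=O)Nc3cccc(S(N)(=O)=O)c3)cc(-c3cccs3)nc21` differs from compound 1 by hydrogen in place of fluoro on an aromatic carbon. Given compound 1 at 50000 nM, compound 4 is expected in this assay near 80000 nM, between 30000 nM and 200000 nM, a step of a 1.6-fold higher number from compound 1 to compound 4 (0.20 log units; within the scatter) that is expected to stay within or only slightly beyond the usual scatter, toward more tolerated if anything. A limit rather than a number is also expected to be quite possible.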

Compound 4, half-maximal cytotoxic concentration: 25000 nM
Compound 4: the middle estimate sits 3.2-fold (0.51 log units) above what was measured; measured number below the stated range.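

Among these compounds, this is the first readable pair at this position. In this assay, hydrogen in place of fluoro on the aromatic carbon ortho to a sulfamoyl group gives a 2.0-fold lower number from compound 1 to compound 4 (0.30 log units; within the scatter). The fluoro is therefore not required for a measured number here: with either atom the sulfamoyl anilide gives a number rather than a limit, and the step gives no sign of better tolerance with hydrogen.

As far as these compounds go, whether chloro, methoxy or an amine on this carbon would move the number beyond the scatter stays open. Steps to compound 2 and compound 3 cannot be read: the limit of > 200000 nM in this assay, at which 2 of the 4 values shown sit.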